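The compounds below may be only part of what the source reports. "The series", "measured", "known", "first", "only" and "open" are said of these compounds alone.

Of the compounds shown here, two have been measured in an in vivo ADME assay on the whole organism (strain BALB/cAnNCrl) for pharmacokinetics, with Mus musculus as the target, at a dose of 10 mg/kg by the oral route; a higher number here means that a larger share of the oral dose reaches the circulation, a lower number that a smaller share of the oral dose reaches the circulation. Compound 1 `Cc1ccc(-n2nc(C(C)(C)C)cc2NC(=O)Nc2ccc(Oc3ccnc4c3n(C)c(=O)n4C)cc2F)cc1` gives 31%, and compound 2 `CC(C)(C)c1cc(NC(=O)Nc2ccc(Oc3ccnc4[nH]c(=O)[nH]c34)cc2F)n(-c2ccccc2)n1` gives 24%, which stands at the bottom of the two numbers shown, although its gap to compound 1 is within the scatter. Compound 3 `Cc1ccc(-n2nc(C(C)(C)C)cc2NC(=O)Nc2ccc(Oc3ccnc4[nH]c(=O)[nH]c34)cc2F)cc1` differs from compound 2 by methyl in place of hydrogen on an aromatic carbon. For the measured compounds named here, no measured step exists for this change, so the expected step of a number 3 percentage points higher from compound 2 to compound 3 (within the scatter) is one that stays within the scatter, in no clear direction. Compound 3 is therefore expected to give about 27%, estimated between 12% and 45%.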

Compound 3, oral bioavailability: 7%
Compound 3: middle estimate off by 20 percentage points, on the high side; the whole stated range lies above it.
By their numbers in this assay, from the lowest: compound 3; then compounds 2 and 1 (each within the scatter of the next).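

In this assay the change from phenyl to 4-methylphenyl brings a number 17 percentage points lower from compound 2 to compound 3 (beyond the scatter) and so, at this place para to a large group, even one methyl is not a neutral change. With the 4-methylphenyl kept, the group on the oxygen also counts: replacing the larger group of compound 1 brings a number 24 percentage points lower from compound 1 to compound 3 (beyond the scatter) and the difference lies beyond the scatter. Nothing available gives a reason for either step.

On these data alone, whether a chlorine or a methoxy at this place would act as methyl does remains open. So does the size of the methyl step when the group on the oxygen is that of compound 1.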